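Catechol vinyl sulfones: lengthening the chain beyond the sulfonyl

The compounds below may be only part of what the source reports. "The series", "measured", "known", "first", "only" and "open" are said of these compounds alone.

Measured in a functional assay on BV-2 cells (Mus musculus) for inhibition, read by Griess assay, with stated times of 3 h and 24 h; on this read-out lower numbers stand for stronger inhibition and higher numbers for weaker inhibition:
compound 1, `O=S(=O)(/C=C/c1ccc(O)c(O)c1)Cc1ccccc1`, gives 11600 nM
compound 2, `O=S(=O)(/C=C/c1ccc(O)c(O)c1)CCc1ccccc1`, gives 30600 nM
compound 3, `O=S(=O)(/C=C/c1ccc(O)c(O)c1)CCCc1ccccc1`, gives 10500 nM

Compound 3 has the lowest number of the three, but its gap to compound 1 is within the scatter, so the two cannot be ordered; only compound 2 stands apart from it, beyond the scatter.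

Compound 4, `O=S(=O)(/C=C/c1ccc(O)c(O)c1)CCCCc1ccccc1`, is the next member of the same series: benzyl in place of phenyl on a saturated chain carbon, three bonds along the chain from a sulfonyl sulfur. The two earlier steps of this kind bear on it directly. Going up the chain by one carbon gave a 2.6-fold higher number from compound 1 to compound 2 (0.42 log units; beyond the scatter), and the next carbon gave a 2.9-fold lower number from compound 2 to compound 3 (0.46 log units; beyond the scatter). The two steps run in opposite directions and are of about the same size, so no trend can be read from them; each further carbon has so far moved the number modestly, but the sign has alternated. For compound 4 the expected step in this assay is therefore one of modest size in either direction, with no step beyond the scatter as the most likely outcome: a 1.4-fold higher number from compound 3 to compound 4 (0.15 log units; within the scatter). The estimate for compound 4 is 15000 nM, with a range from 6000 nM to 40000 nM, wide enough to cover a move of the size seen in either earlier step.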

Compound 4, half-maximal inhibitory concentration: 19800 nM
Beside the measured number, compound 4's estimate is 1.3-fold (0.12 log units) below it; the measured number falls inside the stated range.
By their numbers in this assay, from the lowest: compounds 3, 1, 4 and 2 (each within the scatter of the next, the first and the last beyond it).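

In this assay, benzyl in place of phenyl on a saturated chain carbon, three bonds along the chain from a sulfonyl sulfur, gives a 1.9-fold higher number from compound 3 to compound 4 (0.28 log units; within the scatter), so the two compounds cannot be ordered and this added carbon has no effect that can be read on this read-out. Going by these compounds alone, the alternation suggested by the earlier steps therefore finds no firm support here, as the last step beyond the scatter remains a 2.9-fold lower number from compound 2 to compound 3 (0.46 log units; beyond the scatter) and the new step does not join it as a further clear swing. The new step does read alike with the first chain extension in the series, so an upward move cannot be ruled out at this place: the same change on two cores in this assay, a 2.6-fold higher number (0.42 log units; beyond the scatter) from compound 1 to compound 2 and a 1.9-fold higher number (0.28 log units; within the scatter) from compound 3 to compound 4, 1.4-fold (0.15 log units) apart, within the scatter of two such steps.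

Open, on these data alone, is whether a longer chain than that of compound 4 would stay within the scatter of it or move the number clearly in either direction. Also open is whether an amine or a carboxylic acid in place of the phenyl would change the picture at any of these chain lengths, since every compound shown carries the same unsubstituted phenyl.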